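The compounds below may be only part of what the source reports. "The series", "measured", "known", "first", "only" and "open" are said of these compounds alone.

Compound 1, `Cc1ccc(C(=O)Nc2cccc(-c3ccnc4c(N)cccc34)c2)cc1C`, reaches only a limit, > 20000 nM, in a functional assay on A375P cells (Homo sapiens) for antiproliferative activity, read by MTT assay, with a stated time of 48 h; on this read-out higher numbers stand for weaker inhibition and lower numbers for stronger inhibition.
Compound 2, `Nc1cccc2c(-c3cccc(NC(=O)c4ccc5c(c4)OCCO5)c3)ccnc12`, gives 860 nM in this assay.

Within the data shown here, compound 2 therefore holds the only real number here; the other value is a limit. Compound 1 sits at the limit of > 20000 nM in this assay, at which 1 of the 2 values shown sits. Compound 3, `Nc1cccc2c(-c3cccc(NC(=O)c4cc5ccccc5s4)c3)ccnc12`, differs from compound 2 by 1-benzothiophen-2-yl in place of 2,3-dihydro-1,4-benzodioxin-6-yl on a carbonyl carbon. Among the measured compounds shown here, only one measured step touches the same carbonyl carbon: an at least 23-fold lower number from compound 1 to compound 2 (1.36 log units; beyond the scatter), a large change that shows how strongly the group on that position can move the read-out. Compound 3 keeps a fused two-ring group on the carbonyl carbon, so it resembles compound 2 more than compound 1, but the ring that enters is aromatic and carries one fewer hydrogen-bond acceptor. A modest weakening is expected for compound 3, a 2.3-fold higher number from compound 2 to compound 3 (0.37 log units; beyond the scatter). Compound 3 is estimated at 2000 nM, with a range from 500 nM to 10000 nM.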

Compound 3, half-maximal inhibitory concentration: > 20000 nM
Compound 3 ended at the assay's limit; the forecaster's own chance of this, stated with the estimate: 15%; middle value at least 10-fold (1.00 log units) away from the limit.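

Replacing 2,3-dihydro-1,4-benzodioxin-6-yl with 1-benzothiophen-2-yl on the carbonyl carbon gives an at least 23-fold higher number from compound 2 to compound 3 (1.36 log units; beyond the scatter), so a fused two-ring group at this position is not enough on its own to keep the activity of compound 2. In this assay, compound 3 gives > 20000 nM, which is a limit of the assay and not a number. The step between compound 1 and compound 3 cannot be read, because both compounds stop at the same limit: the limit of > 20000 nM in this assay, at which 2 of the 3 values shown sit.

The compounds shown leave open whether the activity of compound 2 depends on the oxygen atoms of its 2,3-dihydro-1,4-benzodioxin-6-yl group or on its six-membered non-aromatic ring. A 3,4-dimethoxyphenyl group on the same carbonyl carbon, which keeps both oxygen atoms without that ring, would help separate the two.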